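Chloro in place of piperidin-1-yl: compound 3 to compound 4

This account rests on a few compounds, and the source may have more. Where it says the series, first, only, none or still open, it means among the compounds named here.

In an ADME assay on Vero cells (Chlorocebus sabaeus) for cytotoxicity, read by neutral red uptake, with a stated time of 48 h (a higher number here means a weaker inhibitor, a lower number a stronger inhibitor), compound 3 (`Cc1cc(NCCCCCCNc2ccnc3cc(Cl)ccc23)nc(N2CCCCC2)n1`) gives 8800 nM and lies within the scatter of compound 1 (`Cc1cc(NCCCCCCNc2ccnc3cc(Cl)ccc23)nc(N2CCN(C)CC2)n1`) at 10400 nM while compound 2 (`Cc1cc(Cl)nc(NCCCCCCNc2ccnc3cc(Cl)ccc23)n1`) stands clearly higher at 49400 nM on the same scale.

Compound 4 (`Cc1cc(NCCCCCCNc2ccnc3cc(Cl)ccc23)nc(Cl)n1`) has chloro in place of piperidin-1-yl on an aromatic carbon, between two ring nitrogen atoms (chloro in place of piperidin-1-yl on an aromatic carbon).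

Among the measured compounds shown here, only one measured step touches this carbon (a 1.2-fold lower number from compound 1 to compound 3 (0.07 log units; within the scatter)). It exchanges 4-methylpiperazin-1-yl for piperidin-1-yl and stays within the scatter, so it says little about losing the ring altogether. For the measured compounds named here, the only other guide is compound 2 (49400 nM), which also carries a chloro on the ring bearing the methyl group. However, compound 2 is not a matched partner of compound 4, and one compound establishes no pattern. The data therefore point weakly towards a higher number, and the uncertainty is wide.

The expected move is upward, with an estimated size of a 2.3-fold higher number from compound 3 to compound 4 (0.36 log units; beyond the scatter) and a range that still reaches the scatter.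

In this assay compound 4 is expected at 20000 nM (estimated range 8000 nM to 50000 nM).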

Compound 4, half-maximal inhibitory concentration: 32700 nM
Beside the measured number, compound 4's estimate is 1.6-fold (0.21 log units) below it; the measured number falls inside the stated range.
By their numbers in this assay, from the lowest: compounds 3 and 1 (each within the scatter of the next); then compounds 4 and 2 (each within the scatter of the next).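

In this assay, this carbon between two ring nitrogen atoms proves sensitive to the kind of change made: exchanging one ring for another gave a 1.2-fold lower number from compound 1 to compound 3 (0.07 log units; within the scatter), but replacing either ring with chloro gave a 3.7-fold higher number from compound 3 to compound 4 (0.57 log units; beyond the scatter) and a 3.1-fold higher number from compound 1 to compound 4 (0.50 log units; beyond the scatter). Both steps lie beyond the scatter, so on these three compounds the ring-bearing pair stands apart from the chloro compound, though the shift is modest in each case. Moving the chloro-bearing pyrimidine's point of attachment gave a 1.5-fold lower number from compound 2 to compound 4 (0.18 log units; within the scatter), which places the two chloro compounds together and shows no separation between the 2-chloro-6-methylpyrimidin-4-yl and 4-chloro-6-methylpyrimidin-2-yl groups; nothing measured alongside these numbers accounts for the shift.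

The compounds shown cannot separate the loss of the ring from the arrival of chloro, and a hydrogen, a methoxy group or an open-chain dimethylamino group at this carbon would help to tell the two apart. On these data alone, how far the step holds with a shorter or longer chain in place of the shared one also remains open.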